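Removing One Methoxy Group from a Dimethoxyphenyl Side Chain

A few compounds are considered here, and "the series" means these few. Any claim that something is new, unique, unknown or untested is made for them only; others in the source may bear on it.

The shared core carries a diamino-substituted bicyclic ring bearing a phenyl group and a benzylamine arm, and the compounds differ in the substituents on that arm. Compound 2 `COc1ccc(CNc2nc3cc(N)cc(N)c3nc2-c2ccccc2)cc1OC` has a 3,4-dimethoxyphenyl arm and, in a functional assay on MDA-MB-435 cells (Homo sapiens) for inhibition, read by sulforhodamine B assay, with a stated time of 48 h (on this read-out higher numbers stand for weaker inhibition of growth and lower numbers for stronger inhibition of growth), compound 2 gives 4070 nM. Compound 3 `COc1cc(CNc2nc3cc(N)cc(N)c3nc2-c2ccccc2)cc(OC)c1OC` adds a third methoxy group; in this assay compound 3 gives 912 nM. The step of a 4.5-fold lower number from compound 2 to compound 3 (0.65 log units; beyond the scatter) is modest but beyond the scatter. Compound 1 `CCOC(=O)[C@H](CCC(=O)O)NC(=O)c1ccc(CNc2nc3cc(N)cc(N)c3nc2-c2ccccc2)cc1` carries a much larger glutamate-derived arm, and in this assay compound 1 gives < 100000 nM, which is a limit of the assay rather than a number. Among the two actual numbers, compound 2 stands highest.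

Going by these compounds, compound 4 `COc1ccc(CNc2nc3cc(N)cc(N)c3nc2-c2ccccc2)cc1` is untested. It differs from compound 2 by hydrogen in place of methoxy on an aromatic carbon. Among the measured compounds shown here, the only measured step bearing on this, from compound 2 to compound 3, shows that adding a methoxy group lowered the number; taking one away is expected to move the number the other way by a similar modest amount. The expected step is a 2.2-fold higher number from compound 2 to compound 4 (0.34 log units; beyond the scatter). Compound 4 is therefore expected to give about 9000 nM, in the range from 3000 nM to 30000 nM.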

Compound 4, concentration for total growth inhibition: 21900 nM
Estimate against measurement, compound 4: 2.4-fold (0.39 log units) below, within the range that was stated.
By their numbers in this assay, from the lowest: compound 3; then compound 2; then compound 4.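

Taking away the methoxy that sits ortho to a methoxy group and meta to a large group, which turns 3,4-dimethoxyphenyl into 4-methoxyphenyl, gives in this assay a 5.4-fold higher number from compound 2 to compound 4 (0.73 log units; beyond the scatter). So this ring position is not indifferent to what it carries, and hydrogen there goes with weaker inhibition of growth than methoxy. The earlier compounds shown here showed only the gain from a third methoxy group; now both single-place steps on this arm, one up and one down, agree that more methoxy groups go with lower numbers.

Going by these compounds, with only hydrogen and methoxy at this position, it stays open whether a hydroxyl, a fluorine, an amine or a longer chain such as ethoxy would serve as well. Nothing measured here speaks to why the number moves with this change.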